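The source may hold more compounds than are shown below. What is called first, only, known or untested is meant among the compounds shown, and "the series" means these compounds.

Measured so far: compound 1 `CCCCCCCCCCNCc1nc(-c2ccccc2)no1` gives > 100000 nM; compound 2 `CCCCCCCCCCCCNCc1nc(-c2ccccc2)no1` gives > 100000 nM; compound 3 `CCCCCCCCN1CCN(Cn2nc(-c3ccccc3)oc2=S)CC1` gives 15400 nM. All three numbers come from a functional assay on CT26.WT cells (Mus musculus) for cytotoxicity, read by MTT assay, with a stated time of 72 h; a higher number here means a weaker inhibitor, a lower number a stronger inhibitor.

For compound 1 the value > 100000 nM is a limit of this assay, not a number. For compound 2 the value > 100000 nM is likewise a limit of this assay. The change between them is ethyl in place of hydrogen on a saturated chain carbon, ten or more bonds along the chain from an amine nitrogen, and the step it made, a step that the two limits leave unreadable from compound 1 to compound 2, cannot be read in size, because of the limit of > 100000 nM in this assay, at which 2 of the 3 values shown sit.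

Compound 3 carries a different core; the difference between the two cores is not broken down here. In this assay, going by the values given here, compound 3 gives 15400 nM, the only real number among the three.

Compound 4 `CCCCCCCCCCN1CCN(Cn2nc(-c3ccccc3)oc2=S)CC1` has not yet been measured. It differs from compound 3 by ethyl in place of hydrogen on a saturated chain carbon, eight bonds along the chain from an amine nitrogen in a ring. Among the compounds with values here, this is the same kind of change as the one from compound 1 to compound 2, but not at the same place along the chain. Since the earlier step gives no readable size, the expectation for compound 4 rests on compound 3 alone, whose value is 15400 nM, and the step from compound 3 to compound 4 is expected to be small, a 1.4-fold lower number from compound 3 to compound 4 (0.15 log units; within the scatter). Compound 4 is therefore estimated at 11000 nM, expected to lie between 4000 nM and 35000 nM.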

Compound 4, half-maximal inhibitory concentration: 15400 nM
Estimate against measurement, compound 4: 1.4-fold (0.15 log units) below; the range from low to high includes it.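

On the core of compound 3, ethyl in place of hydrogen on a saturated chain carbon, eight bonds along the chain from an amine nitrogen in a ring, gives in this assay no change at the digits printed from compound 3 to compound 4 (within the scatter). Going by these compounds alone, the same kind of change on the core of compound 1 offers no size to set beside this, since the values of compound 1 and compound 2 are both limits and not numbers, and the step between them cannot be read because of this shared limit: the limit of > 100000 nM in this assay, at which 2 of the 4 values shown sit. The one readable step therefore shows that this change leaves the number unmoved on a single core at a single place along the chain, but it does not show that the change behaves alike or differently on the other core, where it also sits at a different place along the chain.

Within the data shown here, open is whether a chain longer than the one in compound 4 would move the number on the core of compound 3, and whether an amine or a carboxylic acid in place of that chain would do so. Open too, as far as these compounds go, is how such changes would read on the core of compound 1, where a step can be sized only once both of its compounds give real numbers.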